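The source may report more compounds than this note shows. Statements on the series, on what has been measured and on what is new or still open speak of the compounds shown alone.

Measured so far in a functional assay on RAW264.7 cells (Mus musculus) for inhibition, read by ELISA, with stated times of 30 min and 24 h; a lower number here means a stronger inhibitor, a higher number a weaker inhibitor:
compound 1, `CN1CCN(c2ccc(NC(=O)c3cc4cc(NC(=O)CCl)ccc4n3Cc3ccc(C(F)(F)F)cc3)cc2)CC1`: 2990 nM
compound 2, `CN1CCN(c2ccc(NC(=O)c3cc4cc(NC(=O)c5ccco5)ccc4n3Cc3ccc(C(F)(F)F)cc3)cc2)CC1`: 2900 nM
compound 3, `CN1CCN(c2ccc(NC(=O)c3cc4cc(N)ccc4n3Cc3ccc(C(F)(F)F)cc3)cc2)CC1`: "not active" (no number reported)

Compound 3 carries the free amine and was reported without a number in this assay. Of the two numbered entries, compound 2 holds the lower one, but the step of a 1.0-fold lower number from compound 1 to compound 2 (0.01 log units; within the scatter) lies within the scatter, so compound 1 and compound 2 are not separable on these data; the only clear contrast is that both acylated compounds return a number while compound 3 does not.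

Compound 4, `CCC(=O)Nc1ccc2c(c1)cc(C(=O)Nc1ccc(N3CCN(C)CC3)cc1)n2Cc1ccc(C(F)(F)F)cc1`, is the next entry for this assay. It differs from compound 2 by ethyl in place of furan-2-yl on a carbonyl carbon.

Within the data shown here, the one step that bears on this change is the exchange of one acyl group for another, from compound 1 to compound 2, and it came out as a 1.0-fold lower number from compound 1 to compound 2 (0.01 log units; within the scatter). Compound 3 shows that removing the acyl group altogether costs the measurable activity, but compound 4 keeps an acyl group. The step to compound 4 replaces a ring by a short chain, which the measured pairs do not cover, so the expectation rests on the two acyl compounds staying close to each other. Compound 4 is therefore expected to sit near compound 2, with the estimated step of a 1.2-fold higher number from compound 2 to compound 4 (0.08 log units; within the scatter). The estimate for compound 4 in this assay is 3500 nM, within 1500 nM to 9000 nM.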

Compound 4, half-maximal inhibitory concentration: 3330 nM
Estimate against measurement, compound 4: 1.1-fold (0.02 log units) above, and the stated range covers the measured number.
By their numbers in this assay, from the lowest: compounds 2, 1 and 4 (each within the scatter of the next).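

In this assay, the carbonyl carbon bound to the amide-type nitrogen carries either a ring or an open chain with no separable difference: ethyl in place of furan-2-yl gives a 1.1-fold higher number from compound 2 to compound 4 (0.06 log units; within the scatter) even though 5 heavy atoms with one five-membered aromatic ring are exchanged for 2 heavy atoms and no ring. The second comparison, methyl in place of chloro on the saturated chain carbon bound to that carbonyl carbon, gives a 1.1-fold higher number from compound 1 to compound 4 (0.05 log units; within the scatter) and so shows that the number seen with compound 1 does not depend on the chloro atom. No measured property is available to explain why these changes leave the number in place.

Still open, going by these compounds, is whether this tolerance extends to a propanoyl analogue carrying an amine or a carboxylic acid, to a longer chain such as butanoyl, or to a six-membered ring such as benzoyl on the same carbonyl carbon. Also open, on these data alone, is whether any acyl group at this position can give a number clearly separated from those of compound 1, compound 2 and compound 4.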